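Series notes: methoxy for chloro, compound 1 to compound 4

This account rests on a few compounds, and the source may have more. Where it says the series, first, only, none or still open, it means among the compounds named here.

Measured so far:
compound 1, `COc1cc2c(/C=C3/C(=O)Nc4ccc(Cl)cc43)c(Cl)n(Cc3cc(OC)c(OC)c(OC)c3)c2cc1C`, 1780 nM
compound 2, `O=C1/C(=C/c2c(Cl)[nH]c3ccccc23)c2ccccc2N1Cc1ccccc1`, 6170 nM
compound 3, `COc1cc2c(/C=C3/C(=O)Nc4cccc(Cl)c43)c(Cl)n(Cc3cc(OC)c(OC)c(OC)c3)c2cc1C`, 1910 nM

In a functional assay on cells (Cancer cell lines, Homo sapiens) for cytotoxicity, with a stated time of 48 h (a lower number here means a stronger inhibitor of growth, a higher number a weaker inhibitor of growth), compound 1 gives the lowest number of the three. Compound 3 lies within the scatter of it (a 1.1-fold higher number from compound 1 to compound 3 (0.03 log units; within the scatter)), while compound 2 gives a clearly higher number. Compound 4, `COc1ccc2c(c1)/C(=C\c1c(Cl)n(Cc3cc(OC)c(OC)c(OC)c3)c3cc(C)c(OC)cc13)C(=O)N2`, differs from compound 1 by methoxy in place of chloro on an aromatic carbon. For the measured compounds named here, no measured step swaps chloro for methoxy; the only step on the same ring, from compound 1 to compound 3, merely relocated the chloro and stayed within the scatter. No step beyond the scatter is therefore expected in this assay, so for compound 4 the expected step is a 1.1-fold higher number from compound 1 to compound 4 (0.03 log units; within the scatter). The estimate for compound 4 is 1900 nM, with a range from 700 nM to 5000 nM.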

Compound 4, concentration for 50% growth inhibition: 14500 nM
The estimate for compound 4 lay 7.6-fold (0.88 log units) below the measured number; the whole stated range lies below it.
By their numbers in this assay, from the lowest: compounds 1 and 3 (each within the scatter of the next); then compound 2; then compound 4.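

In this assay, the exchange of methoxy for chloro on this aromatic carbon gives an 8.1-fold higher number from compound 1 to compound 4 (0.91 log units; beyond the scatter), so the group held here matters. Relocating the chloro gave only a 1.1-fold higher number from compound 1 to compound 3 (0.03 log units; within the scatter), so this ring tolerates that move but not this exchange. No measurement available accounts for the change. From the compounds shown here alone, it remains open whether fluoro, methyl or an amine on this carbon would read like compound 1 or like compound 4. A single exchange cannot show whether losing chloro or gaining methoxy drives the step.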